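This account rests on a few compounds, and the source may have more. Where it says the series, first, only, none or still open, it means among the compounds named here.

The measured compounds:

compound 1, `Oc1ccccc1/C=C/c1ccccc1O`: 24.3 ug/mL
compound 2, `Nc1ccccc1/C=C/c1ccccc1O`: 27 ug/mL
compound 3, `COc1ccccc1/C=C/c1ccccc1O`: 15 ug/mL

All three were run in an ADME assay on HEK293 cells (Homo sapiens) for inhibition, read by MTT assay, with a stated time of 2 days; on this read-out higher numbers stand for weaker inhibition and lower numbers for stronger inhibition. On those numbers compound 3 sits at the low end of the three, yet neither neighbour is separated from it by more than the usual spread: a 1.6-fold lower number from compound 1 to compound 3 (0.21 log units; within the scatter) and a 1.8-fold lower number from compound 2 to compound 3 (0.26 log units; within the scatter) both remain within the scatter, so the three compounds cannot be told apart with confidence.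

Compound 4, `COc1ccccc1/C=C/c1ccccc1N`, has not yet been measured. It is related to compound 3 by a single change: amino in place of hydroxy on an aromatic carbon. The same exchange has already been seen once in this set, between compound 1 and compound 2, where a 1.1-fold higher number from compound 1 to compound 2 (0.05 log units; within the scatter). For the measured compounds named here, that single precedent is the only measured step that bears directly on the change, and it was flat. On that basis the step from compound 3 to compound 4 is expected to be small, a 1.1-fold higher number from compound 3 to compound 4 (0.05 log units; within the scatter), with no direction beyond the scatter asserted. Compound 4 is accordingly estimated to give 17 ug/mL in this assay, with an expected range from 8 ug/mL to 35 ug/mL.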

Compound 4, half-maximal inhibitory concentration: 2.1 ug/mL
The estimate for compound 4 lay 8.1-fold (0.91 log units) above the measured number; the whole stated range lies above it.
By their numbers in this assay, from the lowest: compound 4; then compounds 3, 1 and 2 (each within the scatter of the next).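

In this assay, the exchange of hydroxy for amino turns out not to be a flat change, and its outcome depends on the core that carries it, with a 7.1-fold lower number from compound 3 to compound 4 (0.85 log units; beyond the scatter), whereas the core of compound 1 showed no such response: the same change on two cores in this assay, a 1.1-fold higher number (0.05 log units; within the scatter) from compound 1 to compound 2 and a 7.1-fold lower number (0.85 log units; beyond the scatter) from compound 3 to compound 4, 7.9-fold (0.90 log units) apart, beyond the scatter of two such steps

The methyl on the oxygen shows the same dependence from the other side, with a 13-fold lower number from compound 2 to compound 4 (1.11 log units; beyond the scatter) where the amino group is present, against a step within the scatter where hydroxy stands in its place: the same change on two cores in this assay, a 1.6-fold lower number (0.21 log units; within the scatter) from compound 1 to compound 3 and a 13-fold lower number (1.11 log units; beyond the scatter) from compound 2 to compound 4, 7.9-fold (0.90 log units) apart, beyond the scatter of two such steps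

Neither change gave a step beyond the scatter on the core of compound 1, yet each gave one once the other was in place, so the two changes do not behave independently in these four compounds.

The compounds shown leave open whether the lower number requires the primary amino group itself, or would persist with a methylamino or dimethylamino group in its place. They also leave open whether the methoxy group is specifically needed, or whether an ethoxy group or a fluorine atom could take its part alongside the amino group.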